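A Methyl on the Phenyl Ring: Small Change Expected

The source may report more compounds than this note shows. Statements on the series, on what has been measured and on what is new or still open speak of the compounds shown alone.

Two compounds share one core and differ only in the group attached to the carbonyl carbon. Compound 1 `CC(=O)Nc1nnc(-c2ccc(O)c(O)c2)s1` carries a methyl there; in a functional assay on A549 cells (Homo sapiens) for cytotoxicity, read by MTT assay, with a stated time of 72 h (a lower number here means a stronger inhibitor, a higher number a weaker inhibitor), compound 1 gives 133000 nM. Among the measured compounds shown here, compound 2 `O=C(Nc1nnc(-c2ccc(O)c(O)c2)s1)c1ccccc1` carries a phenyl instead, and in this assay compound 2 gives 13000 nM, which is the lowest of the two numbers measured so far, because a 10-fold lower number from compound 1 to compound 2 (1.01 log units; beyond the scatter).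

Compound 3 `Cc1ccc(C(=O)Nc2nnc(-c3ccc(O)c(O)c3)s2)cc1` is the next step: methyl in place of hydrogen on an aromatic carbon, so the phenyl becomes a 4-methylphenyl. For the measured compounds named here, no measured step touches this ring, so only the position of compound 2 can guide the expectation. Replacing methyl by phenyl at the carbonyl was a large step, but adding a single carbon to that phenyl is a much smaller alteration, so the expected step from compound 2 to compound 3 in this assay is a 1.3-fold lower number from compound 2 to compound 3 (0.11 log units; within the scatter), within the usual scatter. Compound 3 is therefore estimated at 10000 nM, with a range from 4000 nM to 30000 nM.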

Compound 3, half-maximal inhibitory concentration: 11800 nM
Estimate against measurement, compound 3: 1.2-fold (0.07 log units) below, within the range that was stated.
By their numbers in this assay, from the lowest: compounds 3 and 2 (each within the scatter of the next); then compound 1.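

In this assay, turning the phenyl into a 4-methylphenyl gives a 1.1-fold lower number from compound 2 to compound 3 (0.04 log units; within the scatter), so a single methyl on this aromatic carbon leaves compound 2 and compound 3 indistinguishable. The large difference from the methyl on the carbonyl carbon remains with this added carbon, with an 11-fold lower number from compound 1 to compound 3 (1.05 log units; beyond the scatter), a step of similar size to a 10-fold lower number from compound 1 to compound 2 (1.01 log units; beyond the scatter). Nothing available here explains this result.

Going by these compounds, it remains open whether this ring position would accept other groups in the same way, such as a methoxy group, an amine, a carboxylic acid or a longer chain, or how a methyl would behave at another position on the ring. The contribution of the two hydroxyl groups on the shared core is also unknown, as they stay the same in all three compounds.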